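The source may report more compounds than this note shows. Statements on the series, on what has been measured and on what is new or still open speak of the compounds shown alone.

Working notes on the series. The shared core carries a variable group on a saturated chain carbon bound to a nitrogen on an aromatic ring, and three analogues have been run in an ADME assay on cells (Homo sapiens) for cytotoxicity, read by polymerase chain reaction, with a stated time of 3 days; a lower number here means that less compound is tolerated, a higher number that more compound is tolerated. Compound 1 `Cc1nc(NCC2CC2)nc(N[C@@H]2C[C@H](CO)[C@@H](O)[C@H]2O)c1-c1nc2ccccc2s1` gives 8000 nM. For compound 2 `Cc1nc(NCC2CCC2)nc(N[C@@H]2C[C@H](CO)[C@@H](O)[C@H]2O)c1-c1nc2ccccc2s1` the result is a limit of the assay, > 25000 nM. Compound 3 `Cc1nc(NCCCC(F)(F)F)nc(N[C@@H]2C[C@H](CO)[C@@H](O)[C@H]2O)c1-c1nc2ccccc2s1` gives 3000 nM. Of the numbers shown, compound 3 stands lowest, with compound 1 its nearest neighbour; the remaining result is a limit. The move from compound 1 to compound 2 gives an at least 3.1-fold higher number from compound 1 to compound 2 (0.49 log units; beyond the scatter).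

Compound 4 `Cc1nc(NCc2ccsc2)nc(N[C@@H]2C[C@H](CO)[C@@H](O)[C@H]2O)c1-c1nc2ccccc2s1` has not yet been run in this assay. The change from compound 3 reads (thiophen-3-yl in place of 3,3,3-trifluoropropyl on a saturated chain carbon bound to a nitrogen on an aromatic ring). Among the compounds with values here, no measured step exchanges the trifluoropropyl group for an aromatic ring at this position; the nearest comparisons are the two steps that lead into compound 3, a 2.7-fold lower number from compound 1 to compound 3 (0.43 log units; beyond the scatter) and an at least 8.3-fold lower number from compound 2 to compound 3 (0.92 log units; beyond the scatter), the latter resting on (the limit of > 25000 nM in this assay, at which 1 of the 3 values shown sits), in which a small saturated ring in place of the trifluoropropyl group goes with a higher number. On that loose analogy a higher number is expected for compound 4, by a 2.3-fold higher number from compound 3 to compound 4 (0.37 log units; beyond the scatter). The estimate for compound 4 in this assay is 7000 nM, within 2500 nM to 25000 nM.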

Compound 4, half-maximal cytotoxic concentration: 6000 nM
For compound 4 the middle estimate is 1.2-fold (0.07 log units) above the measured one, and the stated range covers the measured number.
By their numbers in this assay, from the lowest: compounds 3, 4 and 1 (each within the scatter of the next, the first and the last beyond it). At a limit, above all of these: compound 2.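

The first aromatic ring at this place gives no separate level in this assay: both a 2.0-fold higher number from compound 3 to compound 4 (0.30 log units; within the scatter) and a 1.3-fold lower number from compound 1 to compound 4 (0.12 log units; within the scatter) lie within the scatter, even though the trifluoropropyl and cyclopropyl analogues differ from each other beyond it. The one gap beyond the scatter for the thiophen-3-yl group is an at least 4.1-fold lower number from compound 2 to compound 4 (0.61 log units; beyond the scatter), and it rests on the result for compound 2, which is a limit: the limit of > 25000 nM in this assay, at which 1 of the 4 values shown sits. The presence of a ring in the variable group therefore does not sort the series, as compound 3, with no ring, lies within the scatter of compound 4, with one, and among these four compounds only the cyclobutyl analogue stands apart.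

Going by these compounds, how far compound 2 really lies from the others stays open, as does whether a cyclopentyl group would read like cyclobutyl or like cyclopropyl. Also open, on these data alone, is whether the thiophen-3-yl result carries over to a phenyl ring or a thiophen-2-yl group, and how a chain ending in an amine or a carboxylic acid would read on this saturated chain carbon.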